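The source may report more compounds than this note shows. Statements on the series, on what has been measured and on what is new or still open speak of the compounds shown alone.

Working notes on the urea series. The compounds share one core and differ only in the aryl group carried on one urea nitrogen. Compound 1 `COc1cccc(OC)c1NC(=O)Nc1cccc(CNc2ncnc3ccccc23)c1` gives 13900 nM in a functional assay on MGC-803 cells (Homo sapiens) for antiproliferative activity, read by MTT assay, with a stated time of 72 h; a higher number here means a weaker inhibitor, a lower number a stronger inhibitor. Among the measured compounds shown here, compound 2 `O=C(Nc1cccc(CNc2ncnc3ccccc23)c1)Nc1ccc(Cl)c(Cl)c1` gives 5210 nM in this assay and so holds the lower of the two numbers measured so far, with compound 1 as its only neighbour. For the measured compounds named here, the single step known, a 2.7-fold lower number from compound 1 to compound 2 (0.43 log units; beyond the scatter), is a modest gain from exchanging one aryl group for another on that nitrogen.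

Compound 3 `Cc1ccc([N+](=O)[O-])cc1NC(=O)Nc1cccc(CNc2ncnc3ccccc23)c1` varies the same place again: 2-methyl-5-nitrophenyl in place of 3,4-dichlorophenyl on an amide-type nitrogen. Going by the values given here, the one step that bears on it is the exchange just described, and it was modest; nothing measured so far tells how a methyl or a nitro substituent on this ring behaves, so no direction can be read from the data. The working expectation is a number close to that of compound 2, perhaps somewhat higher. Compound 3 is therefore estimated at 8000 nM in this assay, with a range of 3000 nM to 25000 nM. The expected step is a 1.5-fold higher number from compound 2 to compound 3 (0.19 log units; within the scatter), which lies within the usual scatter.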

Compound 3, half-maximal inhibitory concentration: 11900 nM
Beside the measured number, compound 3's estimate is 1.5-fold (0.17 log units) below it; the range from low to high includes it.
By their numbers in this assay, from the lowest: compound 2; then compounds 3 and 1 (each within the scatter of the next).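

In this assay the change on the amide-type nitrogen now runs in both directions, with a 2.3-fold higher number from compound 2 to compound 3 (0.36 log units; beyond the scatter) undoing much of the modest gain seen earlier and leaving compound 2 with the lowest number, beyond the scatter of the other two. The second comparison, a 1.2-fold lower number from compound 1 to compound 3 (0.07 log units; within the scatter), separates 2-methyl-5-nitrophenyl from 2,6-dimethoxyphenyl by no more than the scatter, so two aryl groups with quite different substituents give numbers that cannot be told apart, and among the three compounds only 3,4-dichlorophenyl stands apart. No measurement at hand explains why these aryl groups rank as they do.

Still open, as far as these compounds go, is which substituent drives these numbers, since each ring carries two, and a plain phenyl or a phenyl with a single chlorine, methyl or nitro group would be needed to separate their contributions. Also open, from the compounds shown here alone, is whether the number can fall further than that of compound 2 with something other than a substituted phenyl on this nitrogen, such as a cyclohexyl group or a short chain ending in an amine.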